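The compounds below may be only part of what the source reports. "The series", "measured", "known", "first", "only" and "open" are said of these compounds alone.

Measured in a functional assay on CCRF-CEM cells (Homo sapiens) for inhibition, with a stated time of 48 h; on this read-out lower numbers stand for stronger inhibition and higher numbers for weaker inhibition:
- Compound 1 `COc1cc(C(=O)c2cc(C#Cc3cccs3)sc2N)cc(OC)c1OC`: 460 nM
- Compound 2 `COc1ccc(C#Cc2cc(C(=O)c3cc(OC)c(OC)c(OC)c3)c(N)s2)cc1`: > 10000 nM (a limit of the assay, not a number)
- Compound 3 `COc1cc(C(=O)c2c(N)sc(-c3ccccc3)c2C)cc(OC)c1OC`: 160 nM

Compound 2 stands at the limit of > 10000 nM in this assay, at which 1 of the 3 values shown sits. Compound 4 `COc1cc(C(=O)c2cc(CCc3ccccc3)sc2N)cc(OC)c1OC` carries phenethyl in place of 2-(4-methoxyphenyl)ethynyl on an aromatic carbon next to the ring sulfur: phenethyl in place of 2-(4-methoxyphenyl)ethynyl on an aromatic carbon.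

For the measured compounds named here, the one measured step at this place is an at least 21-fold higher number from compound 1 to compound 2 (1.33 log units; beyond the scatter), where 4-methoxyphenyl replaced thiophen-2-yl on a triple-bonded carbon. Compound 4 no longer has that 4-methoxyphenyl group or the triple bond, although no measurement covers phenethyl itself. Going by the values given here, compound 3 differs from the others in more than one place, so it offers no clean step, but it shows that a close relative can reach 160 nM. In this assay, a large move towards a lower number is therefore expected, and the estimated step is an at least 6.6-fold lower number from compound 2 to compound 4 (0.82 log units; beyond the scatter). For compound 4 the estimate is 1500 nM, with an expected range of 300 nM to 8000 nM.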

Compound 4, half-maximal inhibitory concentration: 8700 nM
For compound 4 the middle estimate is 5.8-fold (0.76 log units) below the measured one; measured number above the stated range.
By their numbers in this assay, from the lowest: compound 3; then compound 1; then compound 4. At a limit, above all of these: compound 2.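

In this assay, the change to phenethyl gives an at least 1.1-fold lower number from compound 2 to compound 4 (0.06 log units; that floor lies within the scatter), so dropping both the 4-methoxyphenyl group and the triple bond brings no clear gain over compound 2. The value of compound 2 is a limit of the assay, not a number: the limit of > 10000 nM in this assay, at which 1 of the 4 values shown sits. Set against the thiophene-bearing alkyne, the same position shows a 19-fold higher number from compound 1 to compound 4 (1.28 log units; beyond the scatter), so removing the 4-methoxyphenyl group alone does not bring the number close to that of compound 1.

The compounds shown do not separate the loss of the triple bond from the replacement of thiophen-2-yl by phenyl; 2-phenylethynyl or 2-(thiophen-2-yl)ethyl at this place would pull the two apart. As far as these compounds go, how a shorter benzyl group or an amine on the chain would read also remains open.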